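This account rests on a few compounds, and the source may have more. Where it says the series, first, only, none or still open, it means among the compounds named here.

Measured so far in an in vitro ADME assay on microsomes from liver (Homo sapiens) for pharmacokinetics, read by LC-MS, with a stated time of 10 min, tested at 1 uM; on this read-out higher numbers stand for fast clearance and lower numbers for slow clearance:
- compound 1 `Cc1ccc(NC(=O)[C@H]2CN(C)C[C@@H]2c2ccc(/C=C/C(=O)Nc3ccccc3N)cc2)cc1` gives 15 mL/min/kg
- compound 2 `COc1ccc(NC(=O)[C@H]2CN(C)C[C@@H]2c2ccc(/C=C/C(=O)Nc3ccccc3N)cc2)cc1` gives 14 mL/min/kg
- compound 3 `CN1C[C@H](C(=O)Nc2ccc(Br)cc2)[C@@H](c2ccc(/C=C/C(=O)Nc3ccccc3N)cc2)C1` gives 3 mL/min/kg

Compound 2 stands second highest of the three numbers in this assay. Its nearest neighbour is compound 1, with a 1.1-fold lower number from compound 1 to compound 2 (0.03 log units; within the scatter); its furthest is compound 3, with a 4.7-fold lower number from compound 2 to compound 3 (0.67 log units; beyond the scatter).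

The next compound is compound 4 `CN1C[C@H](C(=O)Nc2ccccc2F)[C@@H](c2ccc(/C=C/C(=O)Nc3ccccc3N)cc2)C1`. The change from compound 2 is 2-fluorophenyl in place of 4-methoxyphenyl on an amide-type nitrogen.

Among the measured compounds shown here, none of the measured steps reproduces this change. The steps that come nearest are a 5.0-fold lower number from compound 1 to compound 3 (0.70 log units; beyond the scatter) and a 4.7-fold lower number from compound 2 to compound 3 (0.67 log units; beyond the scatter), where a halogen replaced the substituent on the aromatic carbon and the number fell modestly. Here a halogen also enters, but at a different place on the ring and with the methoxy gone altogether, so the size and direction of the step are uncertain. The expected step is a small fall, a 1.4-fold lower number from compound 2 to compound 4 (0.15 log units; within the scatter), possibly within the scatter. Compound 4 is estimated at 10 mL/min/kg, with a range from 4 mL/min/kg to 24 mL/min/kg.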

Compound 4, clearance: 10 mL/min/kg
The estimate for compound 4 equals the measured number at the digits printed, and the stated range covers the measured number.
By their numbers in this assay, from the lowest: compound 3; then compounds 4, 2 and 1 (each within the scatter of the next).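

In this assay, among the compounds shown here, the first change of the whole aryl group on the amide-type nitrogen gives a 1.4-fold lower number from compound 2 to compound 4 (0.15 log units; within the scatter) and a 1.5-fold lower number from compound 1 to compound 4 (0.18 log units; within the scatter), so 2-fluorophenyl reads the same as 4-methoxyphenyl and 4-methylphenyl within the scatter. The 4-bromophenyl of compound 3 stands apart, with a 3.3-fold higher number from compound 3 to compound 4 (0.52 log units; beyond the scatter), and compound 4 shows that a halogen on this aryl ring does not always go with the low number of compound 3. No measured data at hand account for this separation.

Compound 3 and compound 4 differ in both the halogen and its place on the ring, so the two contributions cannot be separated. From the compounds shown here alone, how a chloro, nitrile or trifluoromethyl group on this ring would read remains open.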